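The source may report more compounds than this note shows. Statements on the series, on what has been measured and on what is new or still open speak of the compounds shown alone.

Three compounds have been measured in a functional assay on 143B cells (Homo sapiens) for antiproliferative activity, read by MTT assay, with a stated time of 48 h; a higher number here means a weaker inhibitor, a lower number a stronger inhibitor:

compound 1 `O=C(/C=C/c1cccc(NC(=O)c2ccccc2Br)c1)c1nc2ccccc2[nH]1` gives 6050 nM
compound 2 `O=C(Nc1cccc(/C=C/C(=O)c2nc3ccccc3[nH]2)c1)c1ccc(Br)cc1` gives 7310 nM
compound 3 `Cc1ccc(C(=O)Nc2cccc(/C=C/C(=O)c3nc4ccccc4[nH]3)c2)cc1` gives 6560 nM

Compound 3 stands second highest of these three numbers. Its nearest neighbour is reached by a 1.1-fold higher number from compound 1 to compound 3 (0.04 log units; within the scatter), its furthest by a 1.1-fold lower number from compound 2 to compound 3 (0.05 log units; within the scatter); both steps lie within the scatter, so the three compounds cannot be told apart on these numbers.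

Compound 4 `COc1cccc(C(=O)Nc2cccc(/C=C/C(=O)c3nc4ccccc4[nH]3)c2)c1` differs from compound 3 in one place: 3-methoxyphenyl in place of 4-methylphenyl on a carbonyl carbon. All three measured steps bear on this change, since each swaps the aryl group on the same carbonyl carbon: a 1.2-fold higher number from compound 1 to compound 2 (0.08 log units; within the scatter), a 1.1-fold higher number from compound 1 to compound 3 (0.04 log units; within the scatter) and a 1.1-fold lower number from compound 2 to compound 3 (0.05 log units; within the scatter). Among the compounds with values here, none of them moves the number beyond the scatter, and no measured step brings in a methoxy group or a hydrogen-bond acceptor at this place. Compound 4 is therefore expected to show no step beyond the scatter, the estimated step being a 1.0-fold higher number from compound 3 to compound 4 (0.00 log units; within the scatter). For compound 4 the estimated value is 6600 nM, with a range from 3300 nM to 13200 nM.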

Compound 4, half-maximal inhibitory concentration: 4610 nM
Compound 4: the middle estimate sits 1.4-fold (0.16 log units) above what was measured; measured number inside the range.
By their numbers in this assay, from the lowest: compounds 4, 1, 3 and 2 (each within the scatter of the next).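

In this assay, 3-methoxyphenyl brings an oxygen and a hydrogen-bond acceptor to this carbonyl carbon, which none of the earlier aryl groups did, yet all three new steps stay within the scatter: a 1.4-fold lower number from compound 3 to compound 4 (0.15 log units; within the scatter) and a 1.6-fold lower number from compound 2 to compound 4 (0.20 log units; within the scatter) and a 1.3-fold lower number from compound 1 to compound 4 (0.12 log units; within the scatter). The place on this carbonyl carbon, whose other neighbour is an amide-type nitrogen, has therefore now taken four different aryl groups, one of them with an acceptor, with no step beyond the scatter and no order among compounds 1, 2, 3 and 4. Nothing at hand speaks to the reason for this flat picture.

On these data alone, whether an amine, a carboxylic acid or a longer chain at this place would move the number beyond the scatter stays open. As far as these compounds go, the shared core is the same in all four compounds, so what a change within it would do is also open.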